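Cyano on the pyrimidine of an acrylamide series

This account rests on a few compounds, and the source may have more. Where it says the series, first, only, none or still open, it means among the compounds named here.

Measured compounds in a functional assay on HepG2 cells (Homo sapiens) for antiproliferative activity, read by MTT assay, with a stated time of 72 h; a higher number here means a weaker inhibitor, a lower number a stronger inhibitor:
compound 1 `COc1cc(N(C)CCN(C)C)c(NC(=O)C=C(C)C)cc1Nc1nccc(-c2cn(C)c3ccccc23)n1`, 5660 nM
compound 2 `CC/C=C\C(=O)Nc1cc(Nc2nccc(-c3cn(C)c4ccccc34)n2)c(OC)cc1N(C)CCN(C)C`, 6670 nM

Compound 2 holds the highest of the two numbers; the nearest is compound 1, and the step of a 1.2-fold higher number from compound 1 to compound 2 (0.07 log units; within the scatter) lies within the scatter. Compound 3 `CC/C=C\C(=O)Nc1cc(Nc2ncc(C#N)c(-c3cn(C)c4ccccc34)n2)c(OC)cc1N(C)CCN(C)C` differs from compound 2 by cyano in place of hydrogen on an aromatic carbon. No measured step touches this position; the only step shown concerns the acyl group and is within the scatter, so it offers no direction. The expected step of a 1.3-fold lower number from compound 2 to compound 3 (0.13 log units; within the scatter) is therefore none beyond the scatter. Compound 3 is estimated at 5000 nM, within 1500 nM to 15000 nM.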

Compound 3, half-maximal inhibitory concentration: 1360 nM
For compound 3 the middle estimate is 3.7-fold (0.57 log units) above the measured one; the measured number lies below the stated range.
By their numbers in this assay, from the lowest: compound 3; then compounds 1 and 2 (each within the scatter of the next).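

In this assay, among the compounds shown here, this is the first change to the series that lies beyond the scatter: cyano in place of hydrogen on the aromatic carbon ortho to the 1-methyl-1H-indol-3-yl group gives a 4.9-fold lower number from compound 2 to compound 3 (0.69 log units; beyond the scatter). The position therefore responds to substitution, whereas the acyl change in a 1.2-fold higher number from compound 1 to compound 2 (0.07 log units; within the scatter) does not separate its two compounds. Nothing available accounts for this step.

As far as these compounds go, whether the step is specific to cyano remains open, and a methyl, an amine or a carboxylic acid at this position would test that. From the compounds shown here alone, it is also open whether cyano gives a similar step alongside the 2-methylprop-1-en-1-yl group of compound 1.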